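This account rests on a few compounds, and the source may have more. Where it says the series, first, only, none or still open, it means among the compounds named here.

Working notes on the thiocarbamate series. Compound 1 `O=[N+]([O-])c1ccc(Sc2ccc(NC(=S)Oc3ccc(O)cc3)cc2)cc1` in a physicochemical assay for acid dissociation, gives 9.21. Compound 2 `Oc1ccc(OC(=S)Nc2ccc(Sc3ccc(C(Cl)(Cl)Cl)cc3)cc2)cc1` in this assay gives 9.22, and compound 3 `Oc1ccc(OC(=S)Nc2ccc(Nc3ccc(C(Cl)(Cl)Cl)cc3)cc2)cc1` in this assay gives 9.23; the three numbers all lie within the scatter of one another. Compound 2 and compound 1 differ by nitro in place of trichloromethyl on an aromatic carbon, and the step measured is a number 0.01 log units lower from compound 2 to compound 1 (within the scatter). How the cores of compound 3 and compound 2 differ is not broken down here. Compound 4 `O=[N+]([O-])c1ccc(Nc2ccc(NC(=S)Oc3ccc(O)cc3)cc2)cc1` has not been measured; it differs from compound 3 by nitro in place of trichloromethyl on an aromatic carbon, the same change as that between compound 2 and compound 1. For compound 4 the expected step is a number 0.01 log units lower from compound 3 to compound 4 (within the scatter), resting on the earlier matching step a number 0.01 log units lower from compound 2 to compound 1 (within the scatter). In this assay compound 4 is estimated at 9.22, with an expected range from 9 to 9.45.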

Compound 4, acid dissociation constant: 9.22
For compound 4 middle estimate and measured number coincide at the digits printed; measured number inside the range.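

In this assay nitro in place of trichloromethyl on an aromatic carbon gives a number 0.01 log units lower from compound 3 to compound 4 (within the scatter), and the earlier matching step is a number 0.01 log units lower from compound 2 to compound 1 (within the scatter), so on these two cores the change carries over without a step beyond the scatter. This does not show a transferable effect of any size, since neither step can be told from scatter, and two cores give no rule for the wider series. Nothing at hand bears on the reason for this result.

On these data alone, whether the same holds for another group at this place, such as an amine or a carboxylic acid, stays open. Also open, as far as these compounds go, is whether it holds on any core beyond these two.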